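The source may report more compounds than this note shows. Statements on the series, on what has been measured and on what is new or still open speak of the compounds shown alone.

Measured so far in an assay on CHO cells for inhibition of Glucagon receptor (Homo sapiens); on this read-out higher numbers stand for weaker inhibition and lower numbers for stronger inhibition:
compound 1, `CCCCCc1c(C(C)C)nc(C(C)C)c(CO)c1-c1ccccc1F`, gives 9000 nM;
compound 2, `CCCCCc1c(C(C)C)nc(C(C)C)c(CO)c1-c1ccc(C)cc1`, gives 1000 nM;
compound 3, `CCCCCc1c(C(C)C)nc(C(C)C)c(CO)c1-c1cccc(OC)c1`, gives 48000 nM.

Compound 3 gives the highest number of the three, beyond the scatter against both others: a 5.3-fold higher number from compound 1 to compound 3 (0.73 log units; beyond the scatter) and a 48-fold higher number from compound 2 to compound 3 (1.68 log units; beyond the scatter). Compound 4, `CCCCCc1c(C(C)C)nc(C(C)C)c(CO)c1-c1ccc(F)c(CO)c1`, differs from compound 3 by 4-fluoro-3-(hydroxymethyl)phenyl in place of 3-methoxyphenyl on an aromatic carbon. Among the compounds with values here, no measured step covers a hydroxymethyl or a fluorine on that ring, so the steps that bear on it are only those into the 3-methoxyphenyl of compound 3, a 48-fold higher number from compound 2 to compound 3 (1.68 log units; beyond the scatter) and a 5.3-fold higher number from compound 1 to compound 3 (0.73 log units; beyond the scatter), both of which rose; leaving that group is expected to lower the number again, though how far the new group settles is uncertain. The expected step is a 12-fold lower number from compound 3 to compound 4 (1.08 log units; beyond the scatter). Compound 4 is estimated at 4000 nM, range 1000 nM to 20000 nM.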

Compound 4, half-maximal inhibitory concentration: 19000 nM
Beside the measured number, compound 4's estimate is 4.8-fold (0.68 log units) below it; low and high end bracket the measured number.
By their numbers in this assay, from the lowest: compound 2; then compound 1; then compound 4; then compound 3.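

Read in this assay, a hydrogen-bond donor now enters on the aromatic carbon opposite the ring nitrogen, and 4-fluoro-3-(hydroxymethyl)phenyl recovers only modestly from 3-methoxyphenyl (a 2.5-fold lower number from compound 3 to compound 4 (0.40 log units; beyond the scatter)). It stays far from 4-methylphenyl (a 19-fold higher number from compound 2 to compound 4 (1.28 log units; beyond the scatter)) and also gives a higher number than 2-fluorophenyl (a 2.1-fold higher number from compound 1 to compound 4 (0.32 log units; beyond the scatter)). Both groups named with a 3-substituent, 3-methoxyphenyl and 4-fluoro-3-(hydroxymethyl)phenyl, therefore give higher numbers than 4-methylphenyl and 2-fluorophenyl.

Going by these compounds, whether the hydroxymethyl or the fluorine drives this step stays open, as does how an aminomethyl or a carboxylic acid on that ring would read. Nothing available accounts for these steps.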